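Swapping the aryl group on a piperazine compound tested for T-type channel inhibition

A few compounds are considered here, and "the series" means these few. Any claim that something is new, unique, unknown or untested is made for them only; others in the source may bear on it.

Compound 1 `CCCc1nc(-c2ccccc2)c(CNCCCN2CCN(c3cccc(OC)c3)CC2)o1`: 36.4%
Compound 2 `CCCc1nc(-c2ccccc2)c(CNCCN2CCN(c3cccc(OC)c3)CC2)o1`: 40.2%

In an assay on HEK293 cells for inhibition of Voltage-dependent T-type calcium channel subunit alpha-1G (Homo sapiens), read by fluorescence, tested at 10 uM (a lower number here means less inhibition, a higher number more inhibition at the concentration tested (going by the name of the read-out)), compound 1 gives 36.4%, the lower of the two numbers at hand, while compound 2 gives 40.2%, a gap that falls within the scatter, so the two are not distinguishable. Compound 3 `CCCc1nc(-c2ccccc2)c(CNCCCN2CCN(c3ccc(C(F)(F)F)cc3)CC2)o1` carries 4-(trifluoromethyl)phenyl in place of 3-methoxyphenyl on an amine nitrogen in a ring, with everything else unchanged. For the measured compounds named here, no measured pair shows what such a swap does, so the size of the step is open. A modest rise beyond the scatter seems as likely as no change. Compound 3 is expected to give about 44%, between 20% and 68%, a step of a number 7.6 percentage points higher from compound 1 to compound 3 (within the scatter).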

Compound 3, a percentage reported as inhibition, at one concentration (the size of the read-out at that concentration, not a potency): 51.6%
Compound 3: the middle estimate sits 7.6 percentage points below what was measured, and the stated range covers the measured number.
By their numbers in this assay, from the lowest: compounds 1 and 2 (each within the scatter of the next); then compound 3.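

In this assay the change from 3-methoxyphenyl to 4-(trifluoromethyl)phenyl on an amine nitrogen in a ring gives a number 15.2 percentage points higher from compound 1 to compound 3 (beyond the scatter) and thus a real difference. The aryl group at this position can therefore alter inhibition, something compounds 1 and 2 could not show, as they share the same aryl group. Nothing measured here explains the rise.

Whether the trifluoromethyl group or its place on the phenyl ring matters remains open, as neither 4-methoxyphenyl nor 3-(trifluoromethyl)phenyl is among these compounds. How an unsubstituted phenyl would compare is also unknown.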